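Hydroxymethyl on the ring carbon of a cyclic hexapeptide

A few compounds are considered here, and "the series" means these few. Any claim that something is new, unique, unknown or untested is made for them only; others in the source may bear on it.

compound 1 `CC(C)C[C@@H]1NC(=O)[C@H](CCCNC(=N)N)NC(=O)[C@H](CCCCN)NC(=O)[C@H](CC(=O)O)NC(=O)[C@H](CCCCN)NC(=O)CCNC1=O` gives 1650 nM
compound 2 `CC(C)C[C@@H]1NC(=O)[C@H](CCCNC(N)=O)NC(=O)[C@H](CCCCN)NC(=O)[C@H](CC(=O)O)NC(=O)[C@H](CCCCN)NC(=O)CCNC1=O` gives 890 nM
compound 3 `CCCC[C@@H]1NC(=O)[C@H](CCCNC(=N)N)NC(=O)[C@H](CCCCN)NC(=O)[C@H](CC(=O)O)NC(=O)[C@H](CCCCN)NC(=O)CCNC1=O` gives 378 nM

All three values come from an assay on COS-7 cells for inhibition of disintegrin and metalloproteinase domain-containing protein 8 (Homo sapiens), read by ELISA, with a stated time of 6 h; on this read-out lower numbers stand for stronger inhibition and higher numbers for weaker inhibition. Compound 2 sits second highest of the three; compound 1 is nearest, compound 3 furthest. Compound 4 `CC(C)C[C@@H]1NC(=O)[C@H](CCCNC(N)=O)NC(=O)[C@H](CCCCN)NC(=O)[C@H](CC(=O)O)NC(=O)[C@H](CCCCN)NC(=O)C[C@H](CO)NC1=O` differs from compound 2 by hydroxymethyl in place of hydrogen on a saturated ring carbon. Neither measured step touches that place: a 1.9-fold lower number from compound 1 to compound 2 (0.27 log units; within the scatter) and a 4.4-fold lower number from compound 1 to compound 3 (0.64 log units; beyond the scatter) both change side chains, not the ring carbon itself. The measured series therefore gives no direct guide for this change. With nothing to anchor a shift in either direction, the expectation for compound 4 is no step beyond the scatter, a 1.0-fold higher number from compound 2 to compound 4 (0.00 log units; within the scatter), with a wide margin. Compound 4 is estimated at 900 nM, in the range 300 nM to 2700 nM.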

Compound 4, half-maximal inhibitory concentration: 192 nM
For compound 4 the middle estimate is 4.7-fold (0.67 log units) above the measured one; measured number below the stated range.
By their numbers in this assay, from the lowest: compounds 4 and 3 (each within the scatter of the next); then compounds 2 and 1 (each within the scatter of the next).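

In this assay, hydroxymethyl in place of hydrogen on the saturated ring carbon next to the ring nitrogen gives a 4.6-fold lower number from compound 2 to compound 4 (0.67 log units; beyond the scatter), with every side chain of compound 2 unchanged. For the compounds shown here, this ring carbon, untouched in the earlier steps, is therefore a place where a small substituent moves the number beyond the scatter, towards stronger inhibition. Nothing available gives a reason for this step.

From the compounds shown here alone, whether methyl, aminomethyl or a carboxylic acid on this ring carbon gives a step of similar size remains open. So does whether hydroxymethyl gives the same step on compound 1 or compound 3.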